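Chloro for fluoro on a methylated piperazine: bioavailability outlook

The source may hold more compounds than are shown below. What is called first, only, known or untested is meant among the compounds shown, and "the series" means these compounds.

Compound 1, `O=C(Nc1ccc2[nH]c(=O)oc2c1)C(=O)N1CCN(c2ccc(F)c(F)c2)CC1`, was examined in an ADME assay on the whole organism (Rattus norvegicus, strain Sprague-Dawley) for pharmacokinetics, using cassette dosing, at a dose of 1 mg/kg by the oral route (a higher number here means that a larger share of the oral dose reaches the circulation, a lower number that a smaller share of the oral dose reaches the circulation), where compound 1 gives 13%. Compound 2, `O=C(Nc1ccc2[nH]c(=O)oc2c1)C(=O)N1CCN(c2ccc(F)c(Cl)c2)CC1`, differs from it by chloro in place of fluoro on an aromatic carbon; that change made the step of a number 11.6 percentage points higher from compound 1 to compound 2 (beyond the scatter), and compound 2 gives 24.6%. Compound 3, `C[C@@H]1CN(C(=O)C(=O)Nc2ccc3[nH]c(=O)oc3c2)CCN1c1ccc(F)c(F)c1`, differs from compound 1 by methyl in place of hydrogen on a saturated ring carbon; this step was a number 12.3 percentage points higher from compound 1 to compound 3 (beyond the scatter), and compound 3 gives 25.3%. Compounds 2 and 3 lie within the scatter of each other.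

Compound 4, `C[C@@H]1CN(C(=O)C(=O)Nc2ccc3[nH]c(=O)oc3c2)CCN1c1ccc(Cl)c(F)c1`, is not yet measured. It differs from compound 3 by chloro in place of fluoro on an aromatic carbon. This is the same kind of change as that from compound 1 to compound 2, but not the same: there the chloro sits meta to a large group, here para to a large group. The two cores differ by methyl in place of hydrogen on a saturated ring carbon.

Resting on the measured step of a number 11.6 percentage points higher from compound 1 to compound 2 (beyond the scatter), a similar but less certain rise is expected, a number 7.7 percentage points higher from compound 3 to compound 4 (within the scatter). Compound 4 is therefore estimated to give 33%, within 18% to 50%.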

Compound 4, oral bioavailability: 32%
For compound 4 the middle estimate is 1 percentage points above the measured one, within the range that was stated.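

In this assay, chloro in place of fluoro, para to a large group, gives a number 6.7 percentage points higher from compound 3 to compound 4 (within the scatter), so on this core the step alone cannot be told apart from no change. Set beside the earlier step on the core of compound 1, the two steps do not measurably differ: the same change on two cores in this assay, a number 11.6 percentage points higher (beyond the scatter) from compound 1 to compound 2 and a number 6.7 percentage points higher (within the scatter) from compound 3 to compound 4, 4.9 percentage points apart, within the scatter of two such steps This agreement shows only that the two results are compatible; it does not show that the change carries the same size of effect to other cores, because only two pairs are available and the chloro also occupies a different place on the ring in each pair.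

Still open, on these data alone, is whether moving chloro to the other ring place on either core alters oral exposure, which would separate the effect of place from that of the core. The compounds shown also leave open how a bromo group, a methoxy group or a nitrile would behave on the aromatic ring, and how an ethyl group would compare with the methyl on the saturated ring.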